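The compounds below may be only part of what the source reports. "The series", "measured", "known", "first", "only" and "open" are said of these compounds alone.

Compound 2 `O=C(Nc1ccncc1)c1ccc(CNC2=C(Cl)C(=O)c3ccccc3C2=O)cc1` carries a pyridin-4-yl group on an amide-type nitrogen. Among the compounds with values here, in a functional assay on MDA-MB-231 cells (Homo sapiens) for antiproliferative activity, read by sulforhodamine B assay, with a stated time of 48 h (a higher number here means a weaker inhibitor of growth, a lower number a stronger inhibitor of growth), compound 2 gives 2900 nM, the only actual number among the values so far. Compound 1 `O=C(Nc1ccc(F)cc1)c1ccc(CNC2=C(Cl)C(=O)c3ccccc3C2=O)cc1`, with 4-fluorophenyl at the same place, reaches only the limit of the assay, > 10000 nM (the limit of > 10000 nM in this assay, at which 1 of the 2 values shown sits). Within the data shown here, the step of an at least 3.4-fold lower number from compound 1 to compound 2 (0.53 log units; beyond the scatter) is the single measured step. Compound 3 `O=C(Nc1ccc2ncccc2c1)c1ccc(CNC2=C(Cl)C(=O)c3ccccc3C2=O)cc1` changes this group again: quinolin-6-yl in place of pyridin-4-yl on an amide-type nitrogen. Among the measured compounds shown here, no measured step covers a quinolin-6-yl ring, so the measured step gives only loose guidance. The estimate for compound 3 is 2000 nM, within 600 nM to 8000 nM, meaning an expected 1.5-fold lower number from compound 2 to compound 3 (0.16 log units; within the scatter).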

Compound 3, concentration for 50% growth inhibition: > 10000 nM
Compound 3: a limit, no number; the forecaster's own chance of this, stated with the estimate: 15%; at least 5.0-fold (0.69 log units) between middle value and limit.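

In this assay, quinolin-6-yl in place of pyridin-4-yl gives an at least 3.4-fold higher number from compound 2 to compound 3 (0.53 log units; beyond the scatter), so this position does not accept every ring that contains nitrogen. Compound 3 still carries a ring nitrogen, so having one in this group is not enough to match the growth inhibition of compound 2. The step between the other two compounds cannot be read, as compound 1 and compound 3 both stand at a limit rather than a number: the limit of > 10000 nM in this assay, at which 2 of the 3 values shown sit.

Going by these compounds, how a pyridin-3-yl ring or a simple aliphatic amine at this position would compare stays open. On these data alone, the true values of compound 1 and compound 3 also remain unknown.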